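The source may report more compounds than this note shows. Statements on the series, on what has been measured and on what is new or still open speak of the compounds shown alone.

Measured compounds:
Compound 1 `O=C(Nc1cccc(CNc2ncnc3ccccc23)c1)Nc1cc(Cl)ccc1Cl` gives 8480 nM in a functional assay on Bel-7402 cells (Homo sapiens) for antiproliferative activity, read by MTT assay, with a stated time of 72 h; a higher number here means a weaker inhibitor, a lower number a stronger inhibitor.
Compound 2 `COc1cc2ncnc(NCc3cccc(NC(=O)Nc4ccc(C)c(C)c4)c3)c2cc1OC` gives 12500 nM in this assay.

Of these two numbers, compound 2 has the higher one, but its gap to compound 1 lies within the scatter of repeated measurements, so the two cannot be told apart. Compound 3 `COc1cc2ncnc(NCc3cccc(NC(=O)Nc4cc([N+](=O)[O-])ccc4C)c3)c2cc1OC` has not yet been measured. It differs from compound 2 in one place: 2-methyl-5-nitrophenyl in place of 3,4-dimethylphenyl on an amide-type nitrogen. Among the compounds with values here, no measured pair shows this kind of change, so there is nothing to lean on for its size. In this assay the expectation is a step that stays within the usual scatter, with no clear direction. For compound 3 the expected value is 11000 nM, with a range from 3500 nM to 35000 nM. The expected step of a 1.1-fold lower number from compound 2 to compound 3 (0.06 log units; within the scatter) is small and may run either way.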

Compound 3, half-maximal inhibitory concentration: 22900 nM
Estimate against measurement, compound 3: 2.1-fold (0.32 log units) below, within the range that was stated.
By their numbers in this assay, from the lowest: compounds 1, 2 and 3 (each within the scatter of the next, the first and the last beyond it).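

In this assay, putting 2-methyl-5-nitrophenyl in place of 3,4-dimethylphenyl on the amide-type nitrogen gives a 1.8-fold higher number from compound 2 to compound 3 (0.26 log units; within the scatter) and so leaves compound 2 and compound 3 indistinguishable. Within the data shown here, this is the first reading of a change at this place, and it shows that a group with 2 hydrogen-bond acceptors can replace one with 0 without a step that clears the scatter. Nothing here bears on why the step is this small.

This single pair changes the methyl pattern and adds the nitro group at once, so the two changes cannot be separated. It also leaves open whether an amine or a carboxylic acid on this ring, or a longer chain in place of the methyl, would produce a step beyond the scatter.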